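Alkoxybenzyl extension in a diaryloxy-ethylamine series

This account rests on a few compounds, and the source may have more. Where it says the series, first, only, none or still open, it means among the compounds named here.

Measured compounds:
compound 1 `COc1cccc(OC)c1OCCNCCOc1ccccc1OCc1cccc(C)c1` 12000 nM
compound 2 `COc1cccc(OC)c1OCCNCCOc1ccccc1OCc1ccc(C)cc1` 7800 nM
compound 3 `CCOc1ccc(COc2ccccc2OCCNCCOc2c(OC)cccc2OC)cc1` 5200 nM

In a functional assay on PC-3 cells (Homo sapiens) for cytotoxicity, read by sulforhodamine B assay (a higher number here means a weaker inhibitor of growth, a lower number a stronger inhibitor of growth), compound 3 gives the lowest number of the three, but only the gap to compound 1 counts: a 2.3-fold lower number from compound 1 to compound 3 (0.36 log units; beyond the scatter) is beyond the scatter, whereas a 1.5-fold lower number from compound 2 to compound 3 (0.18 log units; within the scatter) is not, so compound 3 and compound 2 cannot be ranked against each other. Between compound 1 and compound 2 a 1.5-fold lower number from compound 1 to compound 2 (0.19 log units; within the scatter) is also within the scatter.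

Compound 4 `COc1cccc(OC)c1OCCNCCOc1ccccc1OCc1ccc(OC(C)C)cc1` is not yet measured in this assay. It differs from compound 3 by methyl in place of hydrogen on a saturated chain carbon bound to an oxygen on an aromatic ring and a saturated chain carbon. The nearest comparison is the step of a 1.5-fold lower number from compound 2 to compound 3 (0.18 log units; within the scatter), where the group on this benzyl ring already grew without a change beyond the scatter; the larger difference a 2.3-fold lower number from compound 1 to compound 3 (0.36 log units; beyond the scatter) combined a shift in position with the group change and is only modest. Extending the alkoxy group by a further carbon is therefore expected to leave the number roughly where compound 3 sits, with at most a small step in either direction.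

Compound 4 is expected to give 4500 nM in this assay, within 2000 nM to 10000 nM, the expected step being a 1.2-fold lower number from compound 3 to compound 4 (0.06 log units; within the scatter).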

Compound 4, concentration for 50% growth inhibition: 2000 nM
Compound 4: middle estimate off by 2.3-fold (0.35 log units), on the high side; the measured number falls inside the stated range.
By their numbers in this assay, from the lowest: compound 4; then compounds 3, 2 and 1 (each within the scatter of the next, the first and the last beyond it).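

Ethoxy to isopropoxy gives a 2.6-fold lower number from compound 3 to compound 4 (0.41 log units; beyond the scatter) in this assay, the first change confined to this alkoxy group that lies beyond the scatter. The longer step from methyl, isopropoxy in place of methyl, gives a 3.9-fold lower number from compound 2 to compound 4 (0.59 log units; beyond the scatter) and is also beyond the scatter, whereas ethoxy in place of methyl gave a 1.5-fold lower number from compound 2 to compound 3 (0.18 log units; within the scatter) and is not, so the group on this benzyl ring can move the number once methyl on the saturated chain carbon is added. With 4-isopropoxyphenyl in place of 3-methylphenyl, a 6.0-fold lower number from compound 1 to compound 4 (0.78 log units; beyond the scatter) is the largest step in the set, and compound 4 is the strongest inhibitor of growth of the four.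

Going by these compounds, whether a straight propoxy group or a longer butoxy chain would match isopropoxy stays open, so the added carbon cannot be separated from the branching. Nothing on hand bears on why this step occurs.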